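Phenyl for pyridinyl on the triazole in an inactive series

The source may report more compounds than this note shows. Statements on the series, on what has been measured and on what is new or still open speak of the compounds shown alone.

Compounds 1 and 2 share one core. Compound 2 `Cc1ccc(S(=O)(=O)Oc2ccc3c(c2C)[C@H](Cn2cc(-c4ccccn4)nn2)[C@@]24CC(=O)[C@@](C)(CC[C@@H]32)C4)cc1` carries pyridin-2-yl on the triazole, while compound 1 `Cc1ccc(S(=O)(=O)Oc2ccc3c(c2C)[C@H](Cn2cc(-c4ccccc4)nn2)[C@@]24CC(=O)[C@@](C)(CC[C@@H]32)C4)cc1` carries phenyl in its place. In a functional assay on SMMC-7721 cells (Homo sapiens) for cytotoxicity, read by MTT assay, with a stated time of 4 days (on this read-out lower numbers stand for stronger inhibition and higher numbers for weaker inhibition), compound 2 reaches only the limit of the assay, > 20000 nM. Compound 1 likewise gives only a limit in this assay, > 20000 nM. The change between them, (phenyl in place of pyridin-2-yl on an aromatic carbon), thus yields a step that the two limits leave unreadable from compound 2 to compound 1; both ends sit at the limit of > 20000 nM in this assay, at which 3 of the 3 values shown sit, so the step has no readable size.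

Compound 3 `C=C1C[C@]23C[C@@]1(O)CC[C@@H]2c1cccc(C)c1[C@@H]3Cn1cc(-c2ccccn2)nn1` belongs to a second core; how this core differs from that of compound 2 is not broken down here. Compound 3 also gives only a limit in this assay, > 20000 nM. Compound 4 `C=C1C[C@]23C[C@@]1(O)CC[C@@H]2c1cccc(C)c1[C@@H]3Cn1cc(-c2ccccc2)nn1` is the unmeasured partner of compound 3 and differs from it by phenyl in place of pyridin-2-yl on an aromatic carbon, the same change as that between compound 2 and compound 1, at a place described in the same words.

The matched pair on the first core gives no direction for this change because compound 2 and compound 1 both stand at the limit of > 20000 nM in this assay, at which 3 of the 3 values shown sit. The step expected on the second core is a step that the limit leaves unreadable from compound 3 to compound 4. Compound 3 stands at a limit, and compound 4 is therefore expected to stay there as well, estimated at 30000 nM. The expected range for compound 4 runs from 15000 nM to 80000 nM.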

Compound 4, half-maximal inhibitory concentration: > 20000 nM
Compound 4 was reported as a limit; the forecaster's own chance of this, stated with the estimate: 85%; the middle value is on the limit's open side.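

No step can be read between compound 3 and compound 4, and the phenyl for pyridin-2-yl change stays without a readable size on either core, because both compounds stand at the same limit: the limit of > 20000 nM in this assay, at which 4 of the 4 values shown sit.

The compounds shown leave open whether this change alters cytotoxicity at all, and which structural feature, if any, would bring a value within the readable range.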